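A few compounds are considered here, and "the series" means these few. Any claim that something is new, unique, unknown or untested is made for them only; others in the source may bear on it.

Measured compounds:
compound 1, `COc1cc2c(cc1OC)C(=O)C(CC1CCN(C(=S)Nc3ccccc3[N+](=O)[O-])CC1)C2`, gives 100 mg/kg in a functional assay on the whole organism (strain Swiss albino) with Mus musculus as the target, in the maximal electroshock model, with a stated time of 0.5 h; a higher number here means that more compound is needed for the effect, a lower number that less compound is needed
compound 2, `COc1cc2c(cc1OC)C(=O)C(CC1CCN(C(=S)Nc3cccc([N+](=O)[O-])c3)CC1)C2`, gives 300 mg/kg
compound 3, `COc1cc2c(cc1OC)C(=O)C(CC1CCN(C(=S)Nc3ccc([N+](=O)[O-])cc3)CC1)C2`, gives 30 mg/kg

Going by the values given here, compound 3 holds the lowest number of the three; the steps of a 3.3-fold lower number from compound 1 to compound 3 (0.52 log units; beyond the scatter) and a 10-fold lower number from compound 2 to compound 3 (1.00 log units; beyond the scatter) both lie beyond the scatter, so compound 3 is the one needing the least compound in this assay. The unmeasured compound 4, `COc1cc2c(cc1OC)C(=O)C(CC1CCN(C(=S)Nc3cccc(Cl)c3)CC1)C2`, differs from compound 3 by 3-chlorophenyl in place of 4-nitrophenyl on an amide-type nitrogen.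

Among the compounds with values here, no measured step exchanges a nitro group for chlorine, so that part of the change is untested here. The measured steps only move the nitro group around the ring: a 3.0-fold higher number from compound 1 to compound 2 (0.48 log units; beyond the scatter), a 3.3-fold lower number from compound 1 to compound 3 (0.52 log units; beyond the scatter) and a 10-fold lower number from compound 2 to compound 3 (1.00 log units; beyond the scatter). Within the data shown here, the 3-nitrophenyl compound 2 carries the highest number of the set, and compound 4 likewise carries a 3-chlorophenyl, which suggests that leaving the 4-nitrophenyl arrangement of compound 3 costs something, while the size of that cost is uncertain since the chlorine for nitro swap has no precedent.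

Compound 4 is therefore expected to give a higher number than compound 3, estimated at 100 mg/kg with a range from 30 mg/kg to 300 mg/kg. The expected step is a 3.3-fold higher number from compound 3 to compound 4 (0.52 log units; beyond the scatter).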

Compound 4, minimum effective dose: 300 mg/kg
Estimate against measurement, compound 4: 3.0-fold (0.48 log units) below; measured number inside the range.
By their numbers in this assay, from the lowest: compound 3; then compound 1; then compounds 2 and 4 (each within the scatter of the next).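

In this assay the exchange of chloro for nitro on an aromatic carbon can now be read directly: no change at the digits printed from compound 2 to compound 4 (within the scatter), so in this pair 3-chlorophenyl and 3-nitrophenyl on the amide-type nitrogen are not told apart by this read-out. Going by these compounds alone, the other two steps place compound 4 on the same side as compound 2: a 10-fold higher number from compound 3 to compound 4 (1.00 log units; beyond the scatter) and a 3.0-fold higher number from compound 1 to compound 4 (0.48 log units; beyond the scatter) both lie beyond the scatter, which shows that the high number seen with 3-nitrophenyl is not confined to the nitro group, and that the 4-nitrophenyl group remains the one with the lowest number in this set. No accompanying measurement accounts for these numbers.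

Whether chloro in place of nitro gives an equally flat reading where the 4-nitrophenyl or 2-nitrophenyl group stands remains open, as the single exchange shown is confined to the 3-substituted pair. Also open, from the compounds shown here alone, is how an unsubstituted phenyl, a methoxy group or an amine on the ring would read on the same nitrogen, and what a carbonyl in place of the thiocarbonyl would do.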